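Ether-to-ester swap on the side chain of compound 3

The compounds below may be only part of what the source reports. "The series", "measured", "known", "first", "only" and "open" are said of these compounds alone.

Among the measured compounds shown here, compound 3 `COCCO[C@H](CC=C(C)C)C1=CC(=O)c2c(O)ccc(O)c2C1=O` gives 43200 nM in a functional assay on DU-145 cells (Homo sapiens) for cytotoxicity, read by MTT assay (a lower number here means a stronger inhibitor, a higher number a weaker inhibitor), the second highest of the three numbers so far. Compound 1 `COC(C)CO[C@H](CC=C(C)C)C1=CC(=O)c2c(O)ccc(O)c2C1=O` gives 16600 nM and compound 2 `CCCC(C)(O)CC(=O)O[C@H](CC=C(C)C)C1=CC(=O)c2c(O)ccc(O)c2C1=O` gives 75000 nM. Compound 4 `CC(=O)OC(C)CO[C@H](CC=C(C)C)C1=CC(=O)c2c(O)ccc(O)c2C1=O` is not yet measured.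

Compound 4 differs from compound 3 by 1-acetoxyethyl in place of methoxymethyl on a saturated chain carbon bound to an oxygen on a saturated carbon; read one bond further out, the change is 2-methoxyethoxy to 2-acetoxypropoxy. For the measured compounds named here, two measured steps bear on it. Adding the branch methyl gave a 2.6-fold higher number from compound 1 to compound 3 (0.42 log units; beyond the scatter) in reverse, so the propyl branch in compound 4 is expected to help. Trading an ether for an ester gave a 4.5-fold higher number from compound 1 to compound 2 (0.65 log units; beyond the scatter), while a 1.7-fold lower number from compound 2 to compound 3 (0.24 log units; within the scatter) stays within the scatter. The two parts pull in opposite directions, so a small step is expected from compound 3 to compound 4 in this assay, likely a somewhat lower number but possibly none beyond the scatter; the expected step is a 1.4-fold lower number from compound 3 to compound 4 (0.16 log units; within the scatter). Compound 4 is therefore estimated at 30000 nM, with a range of 10000 nM to 90000 nM.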

Compound 4, half-maximal inhibitory concentration: 16600 nM
Beside the measured number, compound 4's estimate is 1.8-fold (0.26 log units) above it; the range from low to high includes it.
By their numbers in this assay, from the lowest: compounds 1 and 4 (each within the scatter of the next); then compounds 3 and 2 (each within the scatter of the next).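

Acetyl in place of methyl on an oxygen on a saturated carbon gives no change at the digits printed from compound 1 to compound 4 (within the scatter), so in this assay the 2-acetoxypropyl chain and the 2-methoxypropyl chain cannot be told apart. An ester in the side chain therefore does not always go with a higher number: 1-acetoxyethyl in place of methoxymethyl gives a 2.6-fold lower number from compound 3 to compound 4 (0.42 log units; beyond the scatter), and 2-acetoxypropyl in place of (2-hydroxy-2-methylpentyl)carbonyl gives a 4.5-fold lower number from compound 2 to compound 4 (0.65 log units; beyond the scatter). No measurement is available to explain these steps.

The compounds shown leave open whether the 2-acetoxyethyl chain, which carries the acetyl without the branch methyl, would stand with compound 3 or with compound 4. Also open, on these data alone, is how an amine, a carboxylic acid or a longer acyl chain such as butanoyl at the chain end would read.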